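The compounds below may be only part of what the source reports. "The series", "measured", "known", "first", "only" and "open" are said of these compounds alone.

Measured compounds:
Compound 1 `CC1=CC[C@H](C(C)(C)NC(=S)N/N=C/c2ccccc2)CC1`: in a functional assay on UACC-62 cells (Homo sapiens) for inhibition, read by sulforhodamine B assay, with a stated time of 48 h (on this read-out higher numbers stand for weaker inhibition of growth and lower numbers for stronger inhibition of growth), compound 1 gives > 100000 nM, which is a limit of the assay and not a number.
Compound 2 `CC1=CC[C@H](C(C)(C)NC(=S)N/N=C/c2ccc(Cl)cc2)CC1`: in this assay compound 2 gives > 100000 nM, which is also a limit.

On the numbers shown, compound 1 stands only at a limit; both recorded values sit at the limit of > 100000 nM in this assay, at which 2 of the 2 values shown sit. The step that the two limits leave unreadable from compound 1 to compound 2, a chloro in place of hydrogen on an aromatic carbon, therefore cannot be given a size. The compound not yet measured is compound 3 `CC1=CC[C@H](C(C)(C)NC(=S)N/N=C/c2cccc([N+](=O)[O-])c2)CC1`, reached from compound 1 by nitro in place of hydrogen on an aromatic carbon. Among the compounds with values here, the one measured step that resembles this change, chloro for hydrogen on an aromatic carbon, yielded no readable size, so neither size nor direction can be taken from it for this assay. With every value at the limit, compound 3 is expected most likely to fall at the limit as well, with an estimated step of a number no higher from compound 1 to compound 3 (the limit leaves the size open). The estimate for compound 3 is 100000 nM, within a range from 30000 nM to 300000 nM.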

Compound 3, concentration for total growth inhibition: > 100000 nM
Compound 3 ended at the assay's limit (the forecaster's own chance of this, stated with the estimate: 75%); the middle value sits exactly at the limit.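

Within the data shown here, compound 1 and compound 3 both stand at a limit of the assay rather than at a number, so no step between them can be read: the limit of > 100000 nM in this assay, at which 3 of the 3 values shown sit.

The compounds shown leave open whether nitro or chloro in place of hydrogen on an aromatic carbon changes growth inhibition at all in this assay.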